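Working notes: 2-ethoxyphenyl in place of cyclopentyl

A few compounds are considered here, and "the series" means these few. Any claim that something is new, unique, unknown or untested is made for them only; others in the source may bear on it.

Measured in a functional assay on HeLa cells (Homo sapiens) for inhibition, read by sulforhodamine B assay; a higher number here means a weaker inhibitor, a lower number a stronger inhibitor:
- compound 1 `O=C1C=C(NCc2ccccc2)C(=O)c2c1nc1n2[C@H]2OC[C@@H](O)[C@H]2OC1`: > 8000 nM (a limit)
- compound 2 `CCc1ccc(NC2=CC(=O)c3nc4n(c3C2=O)[C@H]2OC[C@@H](O)[C@H]2OC4)cc1`: 3990 nM
- compound 3 `O=C1C=C(NC2CCCC2)C(=O)c2c1nc1n2[C@H]2OC[C@@H](O)[C@H]2OC1`: > 16000 nM (a limit)

Compound 3 has only a limit, > 16000 nM, and no number. Compound 4 `CCOc1ccccc1NC1=CC(=O)c2nc3n(c2C1=O)[C@H]1OC[C@@H](O)[C@H]1OC3` differs from it as follows: 2-ethoxyphenyl in place of cyclopentyl on an amine nitrogen. In words, 2-ethoxyphenyl stands in place of cyclopentyl on an amine nitrogen. The closest measured change runs the opposite way: an at least 4.0-fold higher number from compound 2 to compound 3 (0.60 log units; beyond the scatter), with cyclopentyl in place of 4-ethylphenyl. The steps of an at least 2.0-fold lower number from compound 1 to compound 2 (0.30 log units; that floor lies within the scatter) and a step that the two limits leave unreadable from compound 1 to compound 3 give no firmer guide. A lower number in this assay, modest or larger and beyond the scatter, is therefore expected. The expected step is an at least 4.0-fold lower number from compound 3 to compound 4 (0.60 log units; beyond the scatter). For compound 4 the estimated value is 4000 nM, with an expected range of 1300 nM to 13000 nM.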

Compound 4, half-maximal inhibitory concentration: 6040 nM
Beside the measured number, compound 4's estimate is 1.5-fold (0.18 log units) below it; low and high end bracket the measured number.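

In this assay, 2-ethoxyphenyl on the amine nitrogen gives an at least 2.6-fold lower number from compound 3 to compound 4 (0.42 log units; beyond the scatter), so a second six-membered aromatic ring, after 4-ethylphenyl, gives a lower number than cyclopentyl. The exchange of the two aromatic groups gives a 1.5-fold higher number from compound 2 to compound 4 (0.18 log units; within the scatter), which leaves them not told apart. Against benzyl the result is an at least 1.3-fold lower number from compound 1 to compound 4 (0.12 log units; that floor lies within the scatter); this step and the one from cyclopentyl are floors only, as compound 1 and compound 3 each hold a limit.

Going by these compounds, how a pyridine ring or a phenyl carrying a carboxylic acid would compare on this amine nitrogen stays open. So does the true size of the gap to cyclopentyl and benzyl.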